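The source may hold more compounds than are shown below. What is called first, only, known or untested is meant among the compounds shown, and "the series" means these compounds.

Measured compounds in a functional assay on HEK293 cells for agonist activity at D(4) dopamine receptor (Homo sapiens), read by FLIPR; on this read-out higher numbers stand for larger maximal responses and lower numbers for smaller maximal responses:
- compound 1 `Cc1ccc(C(=O)NCN2CCC(c3cccc[n+]3[O-])CC2)cc1C` gives 65%
- compound 2 `C=Cc1cccc(C(=O)NCN2CCC(c3cccc[n+]3[O-])CC2)c1` gives 63%
- compound 3 `N#Cc1cccc(C(=O)NCN2CCC(c3cccc[n+]3[O-])CC2)c1` gives 69%

All three share the same core and differ only in the aryl group on the carbonyl carbon. Compound 3 holds the highest of the three numbers, but its separation from the others is small: the step of a number 4 percentage points higher from compound 1 to compound 3 (within the scatter) and the step of a number 6 percentage points higher from compound 2 to compound 3 (within the scatter) are both within the scatter, as is a number 2 percentage points lower from compound 1 to compound 2 (within the scatter). On the numbers shown the three compounds cannot be ordered in this assay.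

Compound 4 `Cc1cc(C)cc(C(=O)NCN2CCC(c3cccc[n+]3[O-])CC2)c1` is not yet measured. It differs from compound 3 in the change (3,5-dimethylphenyl in place of 3-cyanophenyl on a carbonyl carbon). Going by the values given here, the steps that bear on it are the exchanges of the aryl group seen so far, in particular a number 4 percentage points higher from compound 1 to compound 3 (within the scatter), which swaps a dimethylphenyl for the cyanophenyl and stays within the scatter. Both other exchanges among the aryl groups are also within the scatter. Nothing here points to a step beyond the scatter in either direction for the return to a dimethylphenyl, though the substitution pattern of compound 4 is new and untested.

The estimate for compound 4 is therefore a step of a number 4 percentage points lower from compound 3 to compound 4 (within the scatter) in this assay, giving an expected value of 65% with a range from 52% to 78%.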

Compound 4, largest response reached (reported as efficacy), in percent of the reference or control that the assay uses: 56%
The estimate for compound 4 lay 9 percentage points above the measured number; measured number inside the range.
By their numbers in this assay, from the lowest: compounds 4, 2, 1 and 3 (each within the scatter of the next, the first and the last beyond it).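

In this assay the aryl group on the carbonyl carbon gives its first step beyond the scatter, a number 13 percentage points lower from compound 3 to compound 4 (beyond the scatter), with 3,5-dimethylphenyl in place of 3-cyanophenyl, so the read-out is not indifferent to this exchange, although the step is modest. The two other new steps, a number 7 percentage points lower from compound 2 to compound 4 (within the scatter) and a number 9 percentage points lower from compound 1 to compound 4 (within the scatter), stay within the scatter, so compound 4 separates only from compound 3 and not from compound 1 or compound 2. No pattern across the aryl groups follows from this, and no measurement shown bears on the reason for the step.

Whether the step follows from the loss of the nitrile or from the entry of the two methyl groups stays open, as the compounds shown hold no change that separates the two. Also open, on these data alone, is how the maximal response would answer to an aryl group carrying an amine or a carboxylic acid at this place, and whether the step from the 3-cyanophenyl group would hold on a different core.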